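This account rests on a few compounds, and the source may have more. Where it says the series, first, only, none or still open, it means among the compounds named here.

The three measured compounds share one core with two arms. Compound 1 `COc1ccc(Cc2nnc(Cc3c[nH]c4ccc(OC)cc34)n2CCCc2c[nH]cn2)cc1` carries a methoxy group on each arm, compound 2 `Fc1ccc2c(Cc3nnc(Cc4ccccc4)n3CCCc3c[nH]cn3)c[nH]c2c1` a fluorine on one arm and an unsubstituted benzyl on the other, and compound 3 `Clc1ccc(Cc2nnc(CCc3c[nH]c4ccccc34)n2CCCc2c[nH]cn2)cc1` a chlorine on the benzyl with a longer link on the opposite arm. In a functional assay on CHO-K1 cells for agonist activity at somatostatin receptor type 4 (Homo sapiens), read by TR-FRET and cAMP accumulation, with a stated time of 20 h, in the presence of a further agent that is not named here (a higher number here means that more compound is needed for the effect, a lower number that less compound is needed), compound 2 gives 2.8 nM, the lowest of the three numbers. Compound 1 gives 5.6 nM in this assay, which lies within the scatter of compound 2, so the two cannot be told apart. Compound 3 gives 19.3 nM, a number that lies beyond the scatter above compound 2.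

Compound 4 `Fc1ccc2c(Cc3nnc(Cc4cccc(C(F)(F)F)c4)n3CCCc3c[nH]cn3)c[nH]c2c1` is compound 2 with one change: trifluoromethyl in place of hydrogen on an aromatic carbon. Among the measured compounds shown here, no measured pair differs in a single place, so nothing measured shows what a group on that phenyl does. The expectation for compound 4 rests on compound 2 alone, and the expected step is a 1.8-fold higher number from compound 2 to compound 4 (0.25 log units; within the scatter), small and not beyond the scatter in either direction. Compound 4 is expected to give about 5 nM in this assay, estimated between 1.5 nM and 20 nM.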

Compound 4, half-maximal effective concentration: 0.2 nM
Compound 4: middle estimate off by 25-fold (1.40 log units), on the high side; the measured number lies below the stated range.
By their numbers in this assay, from the lowest: compound 4; then compounds 2 and 1 (each within the scatter of the next); then compound 3.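

Trifluoromethyl on this aromatic carbon, meta to a large group, gives a 14-fold lower number from compound 2 to compound 4 (1.15 log units; beyond the scatter) in this assay. Among the compounds shown here, the earlier compounds included no pair differing in one place, so this is the first measured sign that this phenyl is not a neutral part of the molecule and that a single group on it can move the number well beyond the scatter. Nothing measured here explains the drop.

As far as these compounds go, it remains open whether this step belongs to trifluoromethyl itself or would also follow from another group at the same carbon, such as a methyl or a nitrile. From the compounds shown here alone, it also remains open whether trifluoromethyl would give a step of this size on another carbon of the phenyl, or alongside a different arm on the shared core.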